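Compound 2 and its 3-fluorophenyl analogue, compound 3

The compounds below may be only part of what the source reports. "The series", "measured", "known", "first", "only" and "open" are said of these compounds alone.

Within the data shown here, in a functional assay on HOS cells (Homo sapiens) for inhibition, with a stated time of 72 h (on this read-out lower numbers stand for stronger inhibition and higher numbers for weaker inhibition), only two compounds have numbers so far. Compound 1 `NC1CCC(Nc2nc(NCc3ccc(Br)cc3)c3ncn(C4CCCC4)c3n2)CC1` gives 995 nM, and compound 2 `NC1CCC(Nc2nc(NCc3ccc(-c4ccccc4)nc3)c3ncn(C4CCCC4)c3n2)CC1` gives 206 nM, the lower of the two numbers. Among the measured compounds shown here, the one measured step is a 4.8-fold lower number from compound 1 to compound 2 (0.68 log units; beyond the scatter), modest in size but beyond the scatter, with 6-phenylpyridin-3-yl in place of 4-bromophenyl.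

Compound 3 `NC1CCC(Nc2nc(NCc3ccc(-c4cccc(F)c4)nc3)c3ncn(C4CCCC4)c3n2)CC1` differs from compound 2 in one place, phenyl to 3-fluorophenyl: fluoro in place of hydrogen on an aromatic carbon. This puts fluoro in place of hydrogen on an aromatic carbon, meta to a large group.

For the measured compounds named here, no measured pair tests a fluoro change, so the evidence is indirect. Going by the values given here, the only guide is a 4.8-fold lower number from compound 1 to compound 2 (0.68 log units; beyond the scatter), which exchanged a whole aryl group at the same end of the molecule. The present edit is far smaller, so a step of that size is not expected here, and no clear direction can be drawn from the data. The expected change is a 1.1-fold lower number from compound 2 to compound 3 (0.04 log units; within the scatter), which would not go beyond the scatter. Compound 3 is estimated at 190 nM, with an expected range of 85 nM to 420 nM.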

Compound 3, half-maximal inhibitory concentration: 44 nM
For compound 3 the middle estimate is 4.3-fold (0.64 log units) above the measured one, and the stated range ends above it.
By their numbers in this assay, from the lowest: compound 3; then compound 2; then compound 1.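

In this assay, the change from phenyl to 3-fluorophenyl gives a 4.7-fold lower number from compound 2 to compound 3 (0.67 log units; beyond the scatter) and adds only one heavy atom, a fluorine with no ring, no charge and no counted hydrogen-bond donor or acceptor. This single-atom edit is therefore enough to move the read-out beyond the scatter on an aromatic carbon of a six-membered aromatic ring of carbon only, meta to a large group. Among these compounds, its step is modest, as is a 4.8-fold lower number from compound 1 to compound 2 (0.68 log units; beyond the scatter), where a whole aryl group changed, so the earlier compounds gave no sign that so small an edit could register at this level. Nothing measured here bears on why the number falls.

Going by these compounds, whether this step belongs to fluoro itself or to any substituent at this place remains open, and a chloro, methoxy or nitrile group in the same place would separate those readings. On these data alone, it is also open whether 3-fluorophenyl would give a step of similar size on a different shared core, or whether a second fluoro on the same ring would lower the number further.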